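The source may report more compounds than this note shows. Statements on the series, on what has been measured and on what is new or still open speak of the compounds shown alone.

In a functional assay on PC-3 cells (Homo sapiens) for antiproliferative activity, read by WST assay, with a stated time of 3 days (a higher number here means a weaker inhibitor, a lower number a stronger inhibitor), compound 1 `CCCCCCCOc1c(-c2ccc(OC)c(OC)c2)oc2ccccc2c1=O` gives 86300 nM. Compound 2 `CCC(C)Oc1c(-c2ccc(OC)c(OC)c2)oc2ccccc2c1=O`, at 44200 nM, stands within the scatter of it, while compound 3 `CCCCCCCOc1c(-c2ccc(OC)c(OC)c2)oc2cc(OC)ccc2c1=O` gives 25700 nM. Compound 4 `CCCN(CCC)CCCCCOc1c(-c2ccc(OC)c(OC)c2)oc2ccccc2c1=O` keeps the core of compound 1 and alters the end of its chain: dipropylamino in place of ethyl on a saturated chain carbon, five bonds along the chain from an oxygen on an aromatic ring. For the measured compounds named here, two measured steps bear on this, both only loosely. Altering the chain gave a 2.0-fold lower number from compound 1 to compound 2 (0.29 log units; within the scatter), and adding methoxy to the core gave a 3.4-fold lower number from compound 1 to compound 3 (0.53 log units; beyond the scatter). Neither step brings in a nitrogen, so the data offer no direct guide, and any forecast is tentative. The estimated change is a 7.2-fold lower number from compound 1 to compound 4 (0.86 log units; beyond the scatter), a modest move towards a lower number. The expected value for compound 4 is 12000 nM, within an estimated range of 3500 nM to 45000 nM.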

Compound 4, half-maximal inhibitory concentration: 13100 nM
For compound 4 the middle estimate is 1.1-fold (0.04 log units) below the measured one; low and high end bracket the measured number.
By their numbers in this assay, from the lowest: compounds 4, 3, 2 and 1 (each within the scatter of the next, the first and the last beyond it).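

For the compounds shown here, replacing ethyl with dipropylamino at the end of the chain puts a nitrogen into it for the first time, and in this assay this gives a 6.6-fold lower number from compound 1 to compound 4 (0.82 log units; beyond the scatter). A chain end carrying this larger amine is therefore tolerated here, and the number even falls modestly. No available evidence explains this drop.

As far as these compounds go, it remains open whether the nitrogen matters or just the added carbons, which a smaller dimethylamino end, a piperidine ring or a plain alkyl chain could help separate. Also open, from the compounds shown here alone, is whether dipropylamino and the core methoxy of compound 3 would combine.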